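The compounds below may be only part of what the source reports. "The series", "measured", "known", "first", "only" and "open" are said of these compounds alone.

Compound 1 `O=C1C=C(NCc2ccccc2)C(=O)c2c1nc1n2[C@H]2OC[C@@H](O)[C@H]2OC1` is tested in a functional assay on HeLa cells (Homo sapiens) for inhibition, read by sulforhodamine B assay; a lower number here means a stronger inhibitor, a higher number a weaker inhibitor. Compound 1 gives only a limit of the assay, > 8000 nM, and no number. Two related compounds carry an aromatic ring directly on the nitrogen: compound 2 `O=C1C(Nc2ccc(C(F)(F)F)cc2)=CC(=O)c2c1nc1n2[C@H]2OC[C@@H](O)[C@H]2OC1` gives 8920 nM in this assay, and compound 3 `CCc1ccc(NC2=CC(=O)c3c(nc4n3[C@H]3OC[C@@H](O)[C@H]3OC4)C2=O)cc1` gives 6510 nM. Going by the values given here, the one measured step between them, a 1.4-fold lower number from compound 2 to compound 3 (0.14 log units; within the scatter), is within the scatter. Compound 1 thus stands at the limit of > 8000 nM in this assay, at which 1 of the 3 values shown sits.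

Compound 4 `O=C1C=C(N2CCC2)C(=O)c2c1nc1n2[C@H]2OC[C@@H](O)[C@H]2OC1` differs from compound 1 in one place: azetidin-1-yl in place of benzylamino on a double-bonded ring carbon. Among the compounds with values here, none of the measured steps concerns this change; the only measured step swaps one group for another on an aromatic ring that compound 4 does not carry, and it was within the scatter. Every measured value in this small set is weak, whether a number or a limit, so no reason appears for a strong inhibitor to emerge. Compound 4 is therefore expected to stay weak, with the step that the limit leaves unreadable from compound 1 to compound 4 expected to be small or none beyond the scatter. The estimate for compound 4 is 10000 nM, within a range from 4000 nM to 30000 nM, with a fair chance that this assay reports only a limit again.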

Compound 4, half-maximal inhibitory concentration: > 16000 nM
Compound 4: only a limit was reported; the forecaster's own chance of this, stated with the estimate: 60%; middle value at least 1.6-fold (0.20 log units) from the limit.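

In this assay compound 1 and compound 4 each give only a limit and no number, so the step between these two compounds cannot be read. The compounds shown leave open how strongly either compound inhibits, and whether azetidin-1-yl in place of benzylamino changes the result at all.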